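Swapping bromo for trifluoromethyl on a shared quinazoline-type core

The source may report more compounds than this note shows. Statements on the series, on what has been measured and on what is new or still open speak of the compounds shown alone.

Compounds measured so far:
- compound 1, `COc1cc2ncnc(Nc3ccccc3F)c2c(OC)c1OC`: "not determined" (no result reported)
- compound 2, `COc1cc2ncnc(Nc3ccc([N+](=O)[O-])cc3)c2c(OC)c1OC`: "not determined" (no result reported)
- compound 3, `COc1cc2ncnc(Nc3ccc(Br)cc3)c2c(OC)c1OC`: 13.8%

The three compounds share one core and differ only in the substituent on the aniline ring attached to it. Among the compounds with values here, in a functional assay on BGC-823 cells (Homo sapiens) for inhibition, read by MTT assay, with a stated time of 72 h, tested at 1 uM (a lower number here means less inhibition of growth, a higher number more inhibition of growth at the concentration tested), compound 3 gives 13.8%, and it is the only compound of the set with a number at all. For compound 1 the result is "not determined" (no result reported), and for compound 2 it is "not determined" (no result reported). So compound 3 stands alone, and its value shows only weak inhibition of growth at the concentration tested.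

Compound 4, `COc1cc2ncnc(Nc3ccc(C(F)(F)F)cc3)c2c(OC)c1OC`, is the next step. The change from compound 3 to compound 4 is trifluoromethyl in place of bromo on an aromatic carbon. Within the data shown here, no step between two measured compounds is available, so there is nothing in the data to show how this assay responds to such a change. Given the low starting point of compound 3 in this assay, the expected step of a number 1.2 percentage points higher from compound 3 to compound 4 (within the scatter) is small, with no clear direction and not beyond the usual scatter. Compound 4 is therefore expected to give about 15% in this assay, with a likely range from 3% to 32%.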

Compound 4, percent growth inhibition at one concentration: 2.4%
Compound 4: the middle estimate sits 12.6 percentage points above what was measured; measured number below the stated range.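

In this assay, within the data shown here, this change gives the first readable step in the set: trifluoromethyl in place of bromo on the aromatic carbon, para to a large group, gives a number 11.4 percentage points lower from compound 3 to compound 4 (beyond the scatter). The position therefore responds to what sits on it, even though a bromine atom and a trifluoromethyl group both carry no ring, no hydrogen-bond donors and no hydrogen-bond acceptors, so that such a swap on this core cannot be assumed to leave the read-out unchanged. The step runs from weak inhibition of growth to weaker still at the single concentration tested, and nothing available here bears on why the number falls.

From the compounds shown here alone, with a single step, it remains open whether the fall belongs to trifluoromethyl itself or would be shared by other replacements for bromo, and compounds 1 and 2 have no number that could help to settle this. An amine, a carboxylic acid or a longer alkyl chain on the same carbon would test whether any group there can raise the inhibition of growth above that of compound 3.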